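Swapping the Distal Ring and Its Effect on Cytotoxicity

The source may report more compounds than this note shows. Statements on the series, on what has been measured and on what is new or still open speak of the compounds shown alone.

Measured so far:
compound 1, `COc1cc(CC(O)c2ccc(-c3ccc(C(F)(F)F)cc3)cc2)c([N+](=O)[O-])cc1OC`: 4100 nM
compound 2, `COc1cc(CC(O)c2ccc(-c3ccccc3[N+](=O)[O-])cc2)c([N+](=O)[O-])cc1OC`: 9500 nM

Two compounds share one core and differ only in the ring attached on an aromatic carbon. In an ADME assay on HeLa Rh cells (Homo sapiens) for cytotoxicity, read by microscopy (on this read-out higher numbers stand for lower toxicity in this test and lower numbers for higher toxicity in this test), compound 1 gives 4100 nM, the lowest of the two numbers and therefore the higher toxicity in this test. Compound 2 gives 9500 nM, and the step of a 2.3-fold higher number from compound 1 to compound 2 (0.36 log units; beyond the scatter) shows that exchanging this ring can move the number by a modest amount.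

Compound 3, `COc1cc(CC(O)c2ccc(-c3ccncc3)cc2)c([N+](=O)[O-])cc1OC`, has not yet been measured. It differs from compound 1 by pyridin-4-yl in place of 4-(trifluoromethyl)phenyl on an aromatic carbon. Within the data shown here, the only step that bears on this change is a 2.3-fold higher number from compound 1 to compound 2 (0.36 log units; beyond the scatter), which replaced the same leaving group at the same place with a different ring. A similar, modest rise toward lower toxicity is expected for compound 3 in this assay, though it may not exceed the scatter.

Compound 3 is estimated at 6000 nM, within 2500 nM to 15000 nM, an expected step of a 1.5-fold higher number from compound 1 to compound 3 (0.17 log units; within the scatter).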

Compound 3, half-maximal cytotoxic concentration: > 263000 nM
Compound 3 gave a limit, no number (the forecaster's own chance of this, stated with the estimate: 10%); at least 43-fold (1.64 log units) between middle value and limit.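

For compound 3 the read-out in this assay is a limit of the assay and not a number: the limit of > 263000 nM in this assay, at which 1 of the 3 values shown sits.

Even so, this place, on an aromatic carbon para to a large group, proves far more sensitive to the choice of ring than the earlier step, a 2.3-fold higher number from compound 1 to compound 2 (0.36 log units; beyond the scatter), could show. Pyridin-4-yl gives an at least 64-fold higher number from compound 1 to compound 3 (1.80 log units; beyond the scatter) and an at least 27-fold higher number from compound 2 to compound 3 (1.44 log units; beyond the scatter), both large and both towards lower toxicity in this test. As far as these compounds go, the true size of these steps remains unknown, since each ends at a limit.

From the compounds shown here alone, whether a plain phenyl or a pyridin-3-yl ring at this place would read like compound 3 stays open, so the role of the ring nitrogen cannot be told apart from the loss of the other groups. Going by these compounds, how an amine or a carboxylic acid on this ring would read also stays open.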